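Aryl hydrazone variation on the shared core: toward compound 4

The source may hold more compounds than are shown below. What is called first, only, known or untested is meant among the compounds shown, and "the series" means these compounds.

The series shares one core and differs only in the aryl group on a carbon with a double bond to nitrogen. Compound 1 `Cn1c(=O)c(=O)n(C2CCCC2)c2nc(N/N=C/c3ccc(O)c(F)c3)ncc21` carries 3-fluoro-4-hydroxyphenyl; in a functional assay on A549 cells (Homo sapiens) for antiproliferative activity, read by MTT assay (a lower number here means a stronger inhibitor, a higher number a weaker inhibitor), compound 1 gives 97800 nM. Compound 2 `Cc1cc(C)c(/C=N/Nc2ncc3c(n2)n(C2CCCC2)c(=O)c(=O)n3C)c(C)c1` carries 2,4,6-trimethylphenyl, and in this assay compound 2 gives 12000 nM, which is an 8.2-fold lower number from compound 1 to compound 2 (0.91 log units; beyond the scatter). Compound 3 `Cn1c(=O)c(=O)n(C2CCCC2)c2nc(N/N=C/c3cccc(O)c3)ncc21` carries 3-hydroxyphenyl. In this assay compound 3 reaches only a limit, > 100000 nM, so its exact value is not known. Against compound 1 the step is an at least 1.0-fold higher number from compound 1 to compound 3 (0.00 log units; that floor lies within the scatter); against compound 2 it is an at least 8.3-fold higher number from compound 2 to compound 3 (0.92 log units; beyond the scatter). Compound 3 therefore stands at the weak end of the measured set, sitting at the limit of > 100000 nM in this assay, at which 1 of the 3 values shown sits.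

Compound 4 `Cn1c(=O)c(=O)n(C2CCCC2)c2nc(N/N=C/c3cc([N+](=O)[O-])ccc3Cl)ncc21` is the next step: 2-chloro-5-nitrophenyl in place of 3-hydroxyphenyl on a carbon with a double bond to nitrogen. The two aryls with a hydrogen-bond donor, in compound 1 and compound 3, sit at or near the limit, while the aryl without one in compound 2 gave the lowest number in this assay. The incoming group likewise carries no hydrogen-bond donor, so a fall in the number of roughly the size seen in an at least 8.3-fold higher number from compound 2 to compound 3 (0.92 log units; beyond the scatter), read in reverse, is expected, with the caveat that the start is only a limit. The expected step is an at least 3.3-fold lower number from compound 3 to compound 4 (0.52 log units; beyond the scatter). Compound 4 is estimated at 30000 nM, within 8000 nM to 150000 nM.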

Compound 4, half-maximal inhibitory concentration: 8780 nM
For compound 4 the middle estimate is 3.4-fold (0.53 log units) above the measured one; measured number inside the range.
By their numbers in this assay, from the lowest: compounds 4 and 2 (each within the scatter of the next); then compound 1. At a limit, above all of these: compound 3.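

In this assay this place on a carbon with a double bond to nitrogen now holds two aryls with 0 hydrogen-bond donors that share no substituent, 2,4,6-trimethylphenyl and 2-chloro-5-nitrophenyl, and the two stand level within the scatter: a 1.4-fold lower number from compound 2 to compound 4 (0.14 log units; within the scatter). Among the compounds shown here, the two aryls carrying a hydroxyl lie well apart from the new group, with an 11-fold lower number from compound 1 to compound 4 (1.05 log units; beyond the scatter) and an at least 11-fold lower number from compound 3 to compound 4 (1.05 log units; beyond the scatter), so across these four compounds the low and high numbers split by the presence of that hydroxyl, with no compound against the split. The second of those steps starts from compound 3, whose value is a limit and not a number: the limit of > 100000 nM in this assay, at which 1 of the 4 values shown sits.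

Each aryl changes more than one substituent at once, so the compounds shown do not separate the loss of the hydroxyl from the gain of chlorine, nitro or methyl groups. A plain phenyl, a methoxyphenyl, a chlorophenyl or a nitrophenyl alone would divide those contributions, and an aminophenyl or a carboxylic acid on the aryl would show whether other donor groups follow the hydroxyl.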